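Bromo in Place of Cyano: Expected Cell Tolerance

This account rests on a few compounds, and the source may have more. Where it says the series, first, only, none or still open, it means among the compounds named here.

Compound 1 `COc1nc(-c2ccc(C#N)cc2)ccc1[C@@H](c1ccccc1)[C@@](O)(CCN(C)C)c1cccc2ccccc12` was tested in a toxicity assay on HeLa cells (Homo sapiens) for cytotoxicity; a lower number here means that less compound is tolerated, a higher number that more compound is tolerated. In this assay compound 1 gives > 64 ug/mL, which is a limit of the assay rather than a measured number. Two close relatives share its core and differ only in one group on the outer aromatic ring. Compound 2 `COc1nc(-c2ccc(F)cc2)ccc1[C@@H](c1ccccc1)[C@@](O)(CCN(C)C)c1cccc2ccccc12` gives > 64 ug/mL in this assay, again a limit. Compound 3 `COc1nc(-c2ccc(C(F)(F)F)cc2)ccc1[C@@H](c1ccccc1)[C@@](O)(CCN(C)C)c1cccc2ccccc12` gives > 64 ug/mL in this assay, also a limit. The steps among them, a step that the two limits leave unreadable from compound 1 to compound 2, a step that the two limits leave unreadable from compound 1 to compound 3 and a step that the two limits leave unreadable from compound 2 to compound 3, cannot be sized because of the limit of > 64 ug/mL in this assay, at which 3 of the 3 values shown sit.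

Compound 4 `COc1nc(-c2ccc(Br)cc2)ccc1[C@@H](c1ccccc1)[C@@](O)(CCN(C)C)c1cccc2ccccc12` has not yet been measured. It differs from compound 1 as follows: bromo in place of cyano on an aromatic carbon. All three measured steps bear on this change, since each also exchanges the group in the same place, yet none of them was readable, so no direction or size beyond the scatter can be drawn from them. The reasonable expectation is that compound 4 also sits at the limit, estimated as 64 ug/mL with a range from 32 ug/mL to 128 ug/mL. The step this estimate implies, a number no higher from compound 1 to compound 4 (the limit leaves the size open), is expected to stay within the scatter.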

Compound 4, half-maximal cytotoxic concentration: > 64 ug/mL
Compound 4 ended at the assay's limit; the forecaster's own chance of this, stated with the estimate: 80%; the middle value sits exactly at the limit.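

Compound 4 adds no readable step to compound 1, compound 2 or compound 3 in this assay, because all four compounds sit at the same assay limit: the limit of > 64 ug/mL in this assay, at which 4 of the 4 values shown sit.

The compounds shown leave open how far these four differ in cell tolerance, and whether any group in this place would give a measured number instead of a limit.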